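The source may report more compounds than this note shows. Statements on the series, on what has been measured and on what is new or still open speak of the compounds shown alone.

Measured compounds:
compound 1 `O=C1C=C(N2CCC2)C(=O)c2c1nc1n2[C@H]2OC[C@@H](O)[C@H]2OC1` — > 16000 nM
compound 2 `Cc1ccc(NC2=CC(=O)c3c(nc4n3[C@H]3OC[C@@H](O)[C@H]3OC4)C2=O)cc1` — > 4000 nM

In a functional assay on MCF7 cells (Homo sapiens) for inhibition, read by sulforhodamine B assay (on this read-out higher numbers stand for weaker inhibition and lower numbers for stronger inhibition), compound 1 gives only a limit, > 16000 nM, not a number; it sits at the limit of > 16000 nM in this assay, at which 1 of the 2 values shown sits. Compound 2 also gives only a limit, > 4000 nM. Compound 3 `O=C1C=C(Nc2ccc(I)cc2)C(=O)c2c1nc1n2[C@H]2OC[C@@H](O)[C@H]2OC1` differs from compound 1 by (4-iodophenyl)amino in place of azetidin-1-yl on a double-bonded ring carbon. Among the measured compounds shown here, with no measured step between these compounds, the step from compound 1 to compound 3 in this assay is expected to be small, with no clear direction beyond the scatter, and the estimate is an at least 1.6-fold lower number from compound 1 to compound 3 (0.20 log units; that floor lies within the scatter). Compound 3 is expected near 10000 nM, between 2000 nM and 40000 nM.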

Compound 3, half-maximal inhibitory concentration: 2230 nM
Compound 3: middle estimate off by 4.5-fold (0.65 log units), on the high side; low and high end bracket the measured number.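

Exchanging azetidin-1-yl for (4-iodophenyl)amino on a double-bonded ring carbon gives an at least 7.1-fold lower number from compound 1 to compound 3 (0.85 log units; beyond the scatter) in this assay, so this position can carry a change that yields a number rather than a limit. The step is a floor, not an exact size, as its starting value is a limit: the limit of > 16000 nM in this assay, at which 1 of the 3 values shown sits. Compound 2 also gives only a limit, > 4000 nM.

Going by these compounds, whether the iodine or the anilino nitrogen and ring matter more stays open. So does how (4-chlorophenyl)amino or an open-chain dimethylamino group would read at this position.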